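Replacing the Pyrazole Amide of Compound 3 with an Isoxazole

The source may report more compounds than this note shows. Statements on the series, on what has been measured and on what is new or still open speak of the compounds shown alone.

In a functional assay on HEK293 cells for agonist activity at growth hormone secretagogue receptor type 1 (Homo sapiens), read by HTRF and inositol phosphate accumulation, with a stated time of 90 min, in the presence of a further agent that is not named here (a lower number here means a smaller maximal response, a higher number a larger maximal response), compound 3 `O=C(N[C@H]1CN(S(=O)(=O)c2ccccc2)C[C@@H]1C(=O)N[C@H]1CCCNC1)c1cc(C2CC2)n[nH]1` gives 81%, the second highest of the three numbers recorded. Compound 2 `Cc1ccc2[nH]c(C(=O)N[C@@H]3CN(S(=O)(=O)c4ccccc4)C[C@H]3C(=O)NCCN(C)C)cc2c1` gives 79%, which lies within the scatter of compound 3, so the two cannot be told apart on this read-out. Compound 1 `Cc1ccc2[nH]c(C(=O)N[C@H]3CCN(S(=O)(=O)N4CCOCC4)C[C@@H]3C(=O)NCCN(C)C)cc2c1` gives 98%, and this stands beyond the scatter above compound 3.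

Compound 4 `O=C(N[C@H]1CN(S(=O)(=O)c2ccccc2)C[C@@H]1C(=O)N[C@H]1CCCNC1)c1cc(-c2ccccc2Cl)on1` has not yet been measured. It differs from compound 3 in one place: a group of 12 heavy atoms (9 carbon, 1 nitrogen, 1 oxygen, 1 chlorine; one five-membered aromatic ring with 2 hetero atoms, one six-membered aromatic ring of carbon only) in place of a group of 8 heavy atoms (6 carbon, 2 nitrogen; one three-membered non-aromatic ring of carbon only, one five-membered aromatic ring with 2 hetero atoms), on a carbonyl carbon. No pair of measured compounds carries this exchange, so its effect on the maximal response has no precedent among these three. The measured numbers spread over only a modest band, and a swap on the carbonyl carbon is expected to remain inside it. Compound 4 is expected to give about 75% in this assay, with a range from 55% to 95%. The step of a number 6 percentage points lower from compound 3 to compound 4 (within the scatter) that this estimate implies is expected to be a small decrease, one that may well fall within the scatter.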

Compound 4, largest response reached (Emax), in percent of the reference or control that the assay uses: 98%
Compound 4: the middle estimate sits 23 percentage points below what was measured, outside the stated range (above it).
By their numbers in this assay, from the lowest: compounds 2 and 3 (each within the scatter of the next); then compounds 1 and 4 (each within the scatter of the next).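

In this assay, for the compounds shown here, the exchange on the carbonyl carbon gives a number 17 percentage points higher from compound 3 to compound 4 (beyond the scatter), the first sign in these compounds that the maximal response is sensitive to the group at this position. The 3-cyclopropyl-1H-pyrazol-5-yl group and its hydrogen-bond donor are thus not required for a high maximal response, as the larger group with a chlorine and a six-membered aromatic ring of carbon only, and with no hydrogen-bond donor, raises the number rather than lowering it. No available evidence accounts for this rise.

The exchange alters the ring, the chlorine and the donor count all at once, and the compounds shown do not separate these changes. They also leave open how a plain phenyl without the chlorine, or a methoxy group in place of the chlorine, would fare at this position.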